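The source may hold more compounds than are shown below. What is called first, only, known or untested is meant among the compounds shown, and "the series" means these compounds.

Measured so far in an ADME assay on S9 fraction from liver (Homo sapiens) for metabolic stability, with a stated time of 1 h; a higher number here means that more of the compound is left, a lower number that less of the compound is left:
compound 1 `N#Cc1cnc(NCc2cncnc2C(F)(F)F)cc1N[C@H]1CC[C@@H](O)CC1`: 76%
compound 2 `CC(C)(F)c1ncncc1CNc1cc(N[C@H]2CC[C@@H](O)CC2)c(C#N)cn1`: 89%

Of these two compounds, compound 2 has the higher number, at 89%. Among the compounds with values here, the only measured step, a number 13 percentage points higher from compound 1 to compound 2 (beyond the scatter), is modest but lies beyond the usual scatter.

The next compound, compound 3 `N#Cc1cnc(NCc2cncnc2-c2ccccc2)cc1N[C@H]1CC[C@@H](O)CC1`, has not yet been measured. It differs from compound 2 in one place: phenyl in place of 1-fluoro-1-methylethyl on an aromatic carbon. In words, this is phenyl in place of 1-fluoro-1-methylethyl on an aromatic carbon.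

Within the data shown here, one measured step bears on this change, as it also swaps the group at this place: a number 13 percentage points higher from compound 1 to compound 2 (beyond the scatter). It shows that a change there can shift the number by a modest amount. Among the measured compounds shown here, no measured compound carries phenyl at this place, so the guidance is indirect. Compound 2, at 89%, has little room left to rise on a scale of compound remaining, so a fall seems more likely than a rise. The expected change is a modest fall, a number 15 percentage points lower from compound 2 to compound 3 (beyond the scatter). For compound 3 the estimate is 74%, with an expected range from 55% to 90%.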

Compound 3, percent of the compound remaining: 42%
For compound 3 the middle estimate is 32 percentage points above the measured one, and the stated range ends above it.
By their numbers in this assay, from the lowest: compound 3; then compound 1; then compound 2.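

The group on this aromatic carbon, next to the ring nitrogen, can move the number much further than the earlier pair suggested: in this assay phenyl in place of 1-fluoro-1-methylethyl gives a number 47 percentage points lower from compound 2 to compound 3 (beyond the scatter) and phenyl in place of trifluoromethyl gives a number 34 percentage points lower from compound 1 to compound 3 (beyond the scatter). Both of these large steps dwarf the modest one between the two fluorine-bearing groups, a number 13 percentage points higher from compound 1 to compound 2 (beyond the scatter), so among these three compounds the choice between an open fluorinated group and a phenyl ring matters more than the choice between the two fluorinated groups. Nothing measured here explains why less of compound 3 is left after the stated time, so the reason for the fall stays unknown.

With only three groups at this place, the compounds shown cannot separate the effect of having an aromatic ring there from the effect of simply having a larger group. On these data alone, how a cyclohexyl ring, a pyridine ring, a plain methyl group or an amine on this carbon would fall relative to these three remains open.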